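Working notes: three measured compounds and one estimate

This account rests on a few compounds, and the source may have more. Where it says the series, first, only, none or still open, it means among the compounds named here.

Measured so far:
compound 1 `CCN(Cc1cccnc1)c1ccc(C(=O)N2CCc3ccc(OS(N)(=O)=O)cc3C2)cc1`: 85.2%
compound 2 `CCN(Cc1ccccn1)c1cccc(C(=O)N2CCc3ccc(OS(N)(=O)=O)cc3C2)c1`: 19.9%
compound 3 `NS(=O)(=O)Oc1ccc2c(c1)CN(C(=O)c1ccc(N3CCN(c4ncccn4)CC3)cc1)CC2`: 41.9%

All three were run in an assay on HEK293 cells for inhibition of Steryl-sulfatase (Homo sapiens), tested at 1 uM; a lower number here means a weaker effect, a higher number a stronger effect of the compound at the concentration tested. Compound 1 gives the highest of the three numbers; compound 3 lies below it by a gap beyond the scatter, and compound 2 lies further below, also beyond the scatter. Compound 4 `CCN(Cc1cccc(Br)c1)c1ccc(C(=O)N2CCc3ccc(OS(N)(=O)=O)cc3C2)cc1` has not yet been measured. Against compound 1 it differs in one place: 3-bromophenyl in place of pyridin-3-yl on a saturated chain carbon bound to a nitrogen on an aromatic ring. Among the measured compounds shown here, no measured pair shows this same change, so the data offer no direct guide to its size. With the rest of the structure kept as in compound 1, the step is expected to be small, within the scatter: a number 1.2 percentage points lower from compound 1 to compound 4 (within the scatter). Compound 4 is accordingly estimated at 84% in this assay, with a range from 65% to 95%.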

Compound 4, a percentage reported as inhibition, at one concentration (the size of the read-out at that concentration, not a potency): 97.2%
Estimate against measurement, compound 4: 13.2 percentage points below; measured number outside the range, above it.
By their numbers in this assay, from the lowest: compound 2; then compound 3; then compound 1; then compound 4.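

In this assay, 3-bromophenyl in place of pyridin-3-yl on a saturated chain carbon bound to a nitrogen on an aromatic ring gives a number 12 percentage points higher from compound 1 to compound 4 (beyond the scatter). The ring nitrogen of pyridin-3-yl, the hydrogen-bond acceptor of the group that leaves, is therefore not needed at this position for a high read-out. Nothing available explains the size of this step.

Still open, as far as these compounds go, is whether the bromine or the carbon-only ring carries the step. Unsubstituted phenyl, 3-chlorophenyl or 3-methoxyphenyl at this place would separate the two.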